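Side-chain swaps on the amino-acid benzyl ester

This account rests on a few compounds, and the source may have more. Where it says the series, first, only, none or still open, it means among the compounds named here.

Measured so far:
compound 1 `NCCCC[C@H](NC(=O)CN(c1nc(Cl)nc2[nH]cnc12)C1CC1)C(=O)OCc1ccccc1` gives 26.1% in a functional assay on the whole organism (Tail, strain ICR) with Mus musculus as the target, in the tail flick test, with a stated time of 30 min, at a dose of 25 umol/kg by the oral route; a lower number here means a weaker effect, a higher number a stronger effect of the compound at the dose given
compound 2 `CC[C@H](C)[C@H](NC(=O)CN(c1nc(Cl)nc2[nH]cnc12)C1CC1)C(=O)OCc1ccccc1` gives 41.4% in this assay
compound 3 `NC(=O)CC[C@H](NC(=O)CN(c1nc(Cl)nc2[nH]cnc12)C1CC1)C(=O)OCc1ccccc1` gives 30.8% in this assay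

Compound 3 stands second highest of the three numbers. The gap a number 4.7 percentage points higher from compound 1 to compound 3 (within the scatter) is within the scatter, so compound 3 and compound 1 cannot be ordered; the gap a number 10.6 percentage points lower from compound 2 to compound 3 (beyond the scatter) is beyond the scatter and modest, so compound 2 sits clearly above compound 3.

The next compound is compound 4 `CC(C)C[C@H](NC(=O)CN(c1nc(Cl)nc2[nH]cnc12)C1CC1)C(=O)OCc1ccccc1`. Its difference from compound 3 is isopropyl in place of carbamoylmethyl on a saturated chain carbon, two bonds along the chain from an amide-type nitrogen and a carbonyl carbon. Both measured steps bear on this change. In a number 10.6 percentage points lower from compound 2 to compound 3 (beyond the scatter) a sec-butyl gave way to a 2-carbamoylethyl and the number fell by a modest amount; compound 4 reverses that direction, putting a branched alkyl back where an amide-bearing chain was. In a number 15.3 percentage points higher from compound 1 to compound 2 (beyond the scatter) a 4-aminobutyl gave way to sec-butyl and the number rose by a modest amount. Two examples only, so the pattern is thin, but both point the same way: a branched alkyl side chain reads higher than a polar one here.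

For compound 4 a modest rise is therefore expected, a number 9.2 percentage points higher from compound 3 to compound 4 (within the scatter), landing near compound 2. The estimated value for compound 4 is 40%, with a range from 28% to 52%.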

Compound 4, a percentage reported as activity, at one dose (the size of the read-out at that dose, not a potency): 33.9%
Compound 4: the middle estimate sits 6.1 percentage points above what was measured; measured number inside the range.
By their numbers in this assay, from the lowest: compounds 1, 3, 4 and 2 (each within the scatter of the next, the first and the last beyond it).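

In this assay, compound 4 does not separate from either compound with a nitrogen-bearing side chain: isopropyl in place of carbamoylmethyl gives a number 3.1 percentage points higher from compound 3 to compound 4 (within the scatter), and isopropyl in place of 3-aminopropyl gives a number 7.8 percentage points higher from compound 1 to compound 4 (within the scatter). Among these compounds, it does not separate from compound 2 either, since isobutyl in place of sec-butyl gives a number 7.5 percentage points lower from compound 2 to compound 4 (within the scatter), so the earlier contrast between alkyl and nitrogen-bearing side chains now rests on compound 2 alone, with compound 4 going against it, and only the steps from compound 2 to compound 1 and to compound 3 remain beyond the scatter. No measurement on hand accounts for these steps.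

The compounds shown leave open whether a side chain ending in a carboxylic acid, a benzyl side chain or a methyl group on this saturated chain carbon would fall beyond the scatter from compound 4. Among the compounds shown here, they also leave open whether the difference between sec-butyl and isobutyl holds up in repeated measurements, as compound 2 is the only compound separated from any other.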